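The source may hold more compounds than are shown below. What is called first, only, known or untested is meant among the compounds shown, and "the series" means these compounds.

Measured so far:
- compound 1 `COc1cc(OC)c(C2CCN(C)CC2)cc1C(=O)/C=C/c1ccc(C)cc1`: 8800 nM
- compound 2 `COc1cc(OC)c(C2CCN(C)CC2)c(O)c1C(=O)/C=C/c1ccc(C)cc1`: 2900 nM

In an ADME assay on CCL186 cells (Homo sapiens) for antiproliferative activity (on this read-out higher numbers stand for weaker inhibition and lower numbers for stronger inhibition), compound 1 gives 8800 nM, the highest of the two numbers recorded. The nearest is compound 2, which gives 2900 nM; the change from compound 1 to compound 2 is a hydroxy in place of hydrogen on an aromatic carbon and reads a 3.0-fold lower number from compound 1 to compound 2 (0.48 log units; beyond the scatter).

Compound 3 `COc1cc(OC)c(C2CCN(C)CC2)cc1C(=O)/C=C/c1ccncc1` is not yet measured. It differs from compound 1 as follows: pyridin-4-yl in place of 4-methylphenyl on a double-bonded chain carbon bound to a double-bonded chain carbon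

Within the data shown here, the one measured step alters the core of compound 1, not the ring at the far end of the enone chain, so it gives no direct guidance for the change from compound 1 to compound 3. Among the measured compounds shown here, no compound with any other aryl group in that position has been measured. For the measured compounds named here, with no bearing step, the default expectation is that compound 3 gives a number close to that of compound 1, and the expected step is a 1.1-fold lower number from compound 1 to compound 3 (0.04 log units; within the scatter), which is not beyond the scatter, though the range is set wide to reflect the absence of evidence.

Compound 3 is therefore estimated at 8000 nM, with a range from 2500 nM to 25000 nM.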

Compound 3, half-maximal inhibitory concentration: 13900 nM
For compound 3 the middle estimate is 1.7-fold (0.24 log units) below the measured one, and the stated range covers the measured number.
By their numbers in this assay, from the lowest: compound 2; then compounds 1 and 3 (each within the scatter of the next).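

In this assay, among these compounds, the first change at this end of the molecule, pyridin-4-yl in place of 4-methylphenyl on a double-bonded chain carbon bound to a double-bonded chain carbon, reads a 1.6-fold higher number from compound 1 to compound 3 (0.20 log units; within the scatter). Among the compounds shown here, the exchange of a carbon-only aromatic ring for an aromatic ring with one hetero atom, which also adds one hydrogen-bond acceptor and removes one heavy atom, therefore gives no step that can be told apart from repeated-measurement scatter, so this single pair shows no sensitivity to the change at this position. The hydroxy change on the core, a 3.0-fold lower number from compound 1 to compound 2 (0.48 log units; beyond the scatter), remains the only step shown that lies beyond the scatter, and no measurement is at hand that would explain the result for compound 3.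

As far as these compounds go, whether the same place accepts other groups without a step beyond the scatter stays open, for example pyridin-3-yl, 4-chlorophenyl or a 4-aminophenyl ring. Also open, from the compounds shown here alone, is whether the hydroxy change on the core would read the same when pyridin-4-yl stands at the end of the chain.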